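The source may report more compounds than this note shows. Statements on the series, on what has been measured and on what is new or still open speak of the compounds shown alone.

Measured compounds in an assay on membranes from HeLa cells for displacement of a labelled ligand from adenosine receptor A3 (Homo sapiens), read by scintillation counting, with a stated time of 180 min, tested at 1 uM; a lower number here means less inhibition, a higher number more inhibition at the concentration tested (going by the name of the read-out):

Compound 1, `CC1=C(C(=O)OC2CCCC2)C(c2cccs2)NC(=O)N1`: 1%
Compound 2, `CC1=C(C(=O)OC2CCCCC2)C(c2cccs2)NC(=O)N1`: 1%

Compound 2 stands level with compound 1 at the digits shown; its nearest neighbour in the set is compound 1, and the step of no change at the digits printed from compound 1 to compound 2 (within the scatter) lies within the scatter of repeated measurements. Both compounds sit at the bottom of the scale in this assay.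

Compound 3, `CC1=C(C(=O)OCC2CC2)C(c2cccs2)NC(=O)N1`, has not yet been measured. It differs from compound 2 in one place: cyclopropylmethyl in place of cyclohexyl on an oxygen next to a carbonyl group. Within the data shown here, the only measured step that bears on this position is no change at the digits printed from compound 1 to compound 2 (within the scatter), where the ring on the oxygen next to the carbonyl group was enlarged by one carbon and the read-out did not move beyond the scatter. Exchanging the cyclohexyl for a cyclopropylmethyl at the same oxygen is a further change of the same group, and on the evidence of that single step no movement beyond the scatter is expected; the step of a number 1 percentage points higher from compound 2 to compound 3 (within the scatter) is therefore estimated to be essentially flat.

Compound 3 is accordingly expected to give 2%, within a range from -6% to 12%.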

Compound 3, a percentage reported as inhibition, at one concentration (the size of the read-out at that concentration, not a potency): 1%
The estimate for compound 3 lay 1 percentage points above the measured number, within the range that was stated.
By their numbers in this assay, from the lowest: compounds 1, 2 and 3 (each within the scatter of the next).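

Replacing the cyclohexyl on an oxygen next to a carbonyl group with cyclopropylmethyl gives no change at the digits printed from compound 2 to compound 3 (within the scatter) in this assay, and replacing the cyclopentyl with the same group gives no change at the digits printed from compound 1 to compound 3 (within the scatter) in the same assay. The earlier compounds shown here showed only that a carbocycle could gain one carbon without moving the read-out beyond the scatter; this result extends that to a change from a six-membered ring of 6 heavy atoms to a cyclopropylmethyl of 4 heavy atoms, with a three-membered ring. No supporting measurement bears on why the read-out stays flat across these three groups.

All three compounds sit at the bottom of the scale at the single concentration tested, so these numbers cannot show whether this position matters for displacement of the labelled ligand or whether the shared core already holds the read-out there. Also open, going by these compounds, is whether an amine, a carboxylic acid or a longer chain in place of these carbocyclic groups would raise the inhibition beyond the scatter.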